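The compounds below may be only part of what the source reports. "The series", "measured", "known", "first", "only" and "open" are said of these compounds alone.

Working notes on the fatty amide series in an assay on microsomes from intestine for inhibition of acyl-CoA:cholesterol acyltransferase (Oryctolagus cuniculus); on this read-out higher numbers stand for weaker inhibition and lower numbers for stronger inhibition. Compound 1 `CCCCCCCC/C=C/CCCCCCCC(=O)Nc1ccccc1C(C)C` gives 600 nM in this assay. Compound 3 `CCCCCCCC/C=C/CCCCCCCC(=O)Nc1cc(C(=O)OC)ccc1OC` gives 430 nM, and the gap between compound 1 and compound 3 lies within the scatter, so compound 1 merely holds the higher of the two numbers. Compound 2 `CCCCCCCC/C=C/CCCCCCCC(=O)Nc1ccccc1C(=O)c1ccccc1` reaches only a limit of the assay, > 10000 nM. The record the limit of > 10000 nM in this assay, at which 1 of the 3 values shown sits, notes that one of the three values sits at this limit. Within the data shown here, the one measured step, an at least 16-fold higher number from compound 1 to compound 2 (1.22 log units; beyond the scatter), shows a large loss when a benzoyl replaces the isopropyl on the aromatic carbon.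

Compound 4 `CCCCCCCC/C=C/CCCCCCCC(=O)Nc1c(C)cccc1OCC` is not yet measured. Against compound 1 the change is a group of 10 heavy atoms (9 carbon, 1 oxygen; one six-membered aromatic ring of carbon only) in place of a group of 9 heavy atoms (9 carbon; one six-membered aromatic ring of carbon only), on an amide-type nitrogen. Among the measured compounds shown here, only the step from compound 1 to compound 2 bears on this position, and it involved a much bulkier entering group; here the entering group is of nearly the same size as the leaving one. Compound 3, carrying an alkoxy and an ester on its ring, gives 430 nM, so an ether oxygen on the ring is tolerated. For compound 4 no step beyond the scatter is expected, a 1.3-fold lower number from compound 1 to compound 4 (0.12 log units; within the scatter). Compound 4 is therefore estimated at 450 nM, with a range from 150 nM to 1500 nM.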

Compound 4, half-maximal inhibitory concentration: 15 nM
For compound 4 the middle estimate is 30-fold (1.48 log units) above the measured one; the whole stated range lies above it.
By their numbers in this assay, from the lowest: compound 4; then compounds 3 and 1 (each within the scatter of the next). At a limit, above all of these: compound 2.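

In this assay, the aryl group on the amide-type nitrogen turns out to matter far more than the near match in size suggested: replacing 2-isopropylphenyl with a group of similar heavy-atom count that adds one oxygen gives a 40-fold lower number from compound 1 to compound 4 (1.60 log units; beyond the scatter). The earlier change to the aryl group of compound 1 showed only a large loss, whereas compound 4 shows that a change here can also give a large gain, so heavy-atom count alone does not predict the outcome at this position. Nothing in the data at hand accounts for the size of this gain.

The aryl group of compound 4 carries both a methyl and an ethoxy group, so the compounds shown do not separate the contribution of either one, or show whether the gain needs both together. Also open, from the compounds shown here alone, is whether the low number would hold with a longer ether such as butoxy, with an amine or a carboxylic acid on the ring, or with a different fatty chain on the same aryl amide.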